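The source may report more compounds than this note shows. Statements on the series, on what has been measured and on what is new or still open speak of the compounds shown alone.

Three compounds share one core and differ only in what sits on the phenyl ring at the end of the chain. Compound 1 `O=C(O)CCCSCCN1C(=O)SC[C@@H]1/C=C/[C@@H](O)Cc1ccccc1` carries no substituent there. In an assay on CHO cells for displacement of a labelled ligand from prostaglandin E2 receptor EP2 subtype (Mus musculus), read by scintillation counting, with a stated time of 60 min (a lower number here means a stronger inhibitor, a higher number a weaker inhibitor), compound 1 gives only a limit, > 10000 nM. Compound 2 `CCCc1cccc(C[C@H](O)/C=C/[C@H]2CSC(=O)N2CCSCCCC(=O)O)c1` carries a propyl group on an aromatic carbon, and in this assay compound 2 also gives only a limit, > 10000 nM. Compound 3 `CCc1cccc(C[C@H](O)/C=C/[C@H]2CSC(=O)N2CCSCCCC(=O)O)c1` carries an ethyl group on an aromatic carbon, and in this assay compound 3 likewise gives only a limit, > 10000 nM. Compound 3 thus stands where every measured compound stands, as the limit of > 10000 nM in this assay, at which 3 of the 3 values shown sit, records, and the steps a step that the two limits leave unreadable from compound 1 to compound 2, a step that the two limits leave unreadable from compound 1 to compound 3 and a step that the two limits leave unreadable from compound 2 to compound 3 are all unreadable. Compound 4 `O=C(O)CCCSCCN1C(=O)SC[C@@H]1/C=C/[C@@H](O)Cc1cccc(C(F)(F)F)c1` differs from compound 3 by trifluoromethyl in place of ethyl on an aromatic carbon. Going by the values given here, no measured step has a readable size, so neither direction nor size can be taken from them. Compound 4 is expected to give about 20000 nM, within a range from 5000 nM to 80000 nM, most likely again as a limit. The expected step that the limit leaves unreadable from compound 3 to compound 4 is itself only a guess.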

Compound 4, inhibition constant: > 10000 nM
Compound 4 was reported as a limit; the forecaster's own chance of this, stated with the estimate: 80%; the middle value lies beyond the limit too.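

Compound 4, like compound 1, compound 2 and compound 3, gives only a limit, so none of the steps to compound 4 can be read; all four compounds sit together at one value: the limit of > 10000 nM in this assay, at which 4 of the 4 values shown sit.

The compounds shown leave open whether any group on the phenyl ring alters the result in this assay.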